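From dimethylcarbamoyl to pyrimidin-2-yl: a half-life estimate

The source may hold more compounds than are shown below. What is called first, only, known or untested is meant among the compounds shown, and "the series" means these compounds.

Measured so far in an ADME assay on the whole organism (strain 129/SvEvBrd x C57BL/6) for metabolic stability, with Mus musculus as the target (a higher number here means that the compound lasts longer, a lower number that the compound disappears faster), are three compounds:
compound 1 `CC(=O)c1nc([C@@H](O)[C@H](O)[C@H](O)CO)c(-c2ccccc2)[nH]1` gives 1.9 h
compound 2 `CN(C)C(=O)c1nc([C@@H](O)[C@H](O)[C@H](O)CO)c[nH]1` gives 4 h
compound 3 `OC[C@@H](O)[C@@H](O)[C@H](O)c1c[nH]c(-c2ncn(Cc3ccccc3)n2)n1` gives 2.4 h

Compound 2 stands level with compound 3 within the usual scatter, and beyond that scatter over compound 1. One change pyrimidin-2-yl in place of dimethylcarbamoyl on an aromatic carbon turns compound 2 into compound 4 `OC[C@@H](O)[C@@H](O)[C@H](O)c1c[nH]c(-c2ncccn2)n1` by putting pyrimidin-2-yl in place of dimethylcarbamoyl on an aromatic carbon. Among the measured compounds shown here, no measured pair shows this change alone, so only a small fall in this assay is expected, within the scatter. Compound 3 also bears an aromatic ring there and gives 2.4 h as the closest guide. The estimated change is a 1.6-fold lower number from compound 2 to compound 4 (0.20 log units; within the scatter) and no more. For compound 4 the expected half-life is 2.5 h with an estimated range from 1.2 h to 5 h overall.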

Compound 4, half-life: 2.4 h
Beside the measured number, compound 4's estimate is 1.0-fold (0.02 log units) above it; low and high end bracket the measured number.
By their numbers in this assay, from the lowest: compounds 1, 3, 4 and 2 (each within the scatter of the next, the first and the last beyond it).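

In this assay this position gives its first single-change comparison, with a 1.7-fold lower number from compound 2 to compound 4 (0.22 log units; within the scatter) for the swap. Pyrimidin-2-yl, with its six-membered aromatic ring, can therefore stand in place of dimethylcarbamoyl, which has no ring, on this aromatic carbon between two ring nitrogen atoms without a step beyond the scatter. Nothing available explains why the half-life holds across this swap. Still open, going by these compounds, is whether a simple amine or a carboxylic acid on this same carbon would also stay within the scatter of compound 2 in this assay.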